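Dropping the Allyloxy Group: From Compound 2 to Compound 4

The compounds below may be only part of what the source reports. "The series", "measured", "known", "first", "only" and "open" are said of these compounds alone.

Compound 2 `C=CCOc1cc(C2=C(c3cc(OC)c(OC)c(OC)c3)C(=O)C(O)C2)ccc1OC` was examined in an ADME assay on MIA PaCa-2 cells (Homo sapiens) for cytotoxicity, read by MTT assay, with a stated time of 72 h; a higher number here means a weaker inhibitor, a lower number a stronger inhibitor. In this assay compound 2 gives only a limit, > 100 ug/mL, and not a number. Compound 1 `COc1ccc(C2=C(c3cc(OC)c(OC)c(OC)c3)C(=O)CC2O[SiH2]C(C)(C)C)cc1OC` likewise reaches only a limit, > 100 ug/mL. Compound 3 `COc1ccc(C2=C(c3cc(OC)c(OC)c(OC)c3)CC(O)C2=O)cc1N` also shows only a limit, > 100 ug/mL. Compound 2 therefore stands with both others at the limit of > 100 ug/mL in this assay, at which 3 of the 3 values shown sit, so no ordering among the three can be read from these data. Compound 4 `COc1ccc(C2=C(c3cc(OC)c(OC)c(OC)c3)C(=O)C(O)C2)cc1` differs from compound 2 by hydrogen in place of allyloxy on an aromatic carbon. For the measured compounds named here, no measured step between compounds covers this change. No shift beyond the usual scatter is expected for a step that the limit leaves unreadable from compound 2 to compound 4, and compound 4 is expected most likely to remain at the limit too. Compound 4 is estimated at 150 ug/mL, within 60 ug/mL to 400 ug/mL.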

Compound 4, half-maximal inhibitory concentration: < 1 ug/mL
Compound 4 gave a limit, no number; the forecaster's own chance of this, stated with the estimate: 75%; at least 150-fold (2.17 log units) between middle value and limit.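

In this assay compound 4 gives < 1 ug/mL, a limit and not a number. For the compounds shown here, removing the allyloxy group from the aromatic carbon ortho to a methoxy group gives an at least 100-fold lower number from compound 2 to compound 4 (2.00 log units; beyond the scatter), the first readable step here, so the group on this carbon matters. Compound 4 stands alone at its end of the range: the limit of < 1 ug/mL in this assay, at which 1 of the 4 values shown sits.

As far as these compounds go, both ends of the step are limits, so its true size stays unknown. From the compounds shown here alone, whether a fluorine atom or an ethoxy group on this carbon would keep the low value also remains open.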